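The source may report more compounds than this note shows. Statements on the series, on what has been measured and on what is new or still open speak of the compounds shown alone.

Three measured compounds share one core and differ only in the halogen carried on a six-membered aromatic ring of carbon only. Compound 1 `O=C(Nc1ccc(Oc2ccnc3[nH]ccc23)cc1)c1cn(-c2ccc(F)cc2)c2ccccc2c1=O` carries a fluoro there, and in a functional assay on HepG2 cells (Homo sapiens) for inhibition, read by MTT assay, with a stated time of 72 h (a lower number here means a stronger inhibitor, a higher number a weaker inhibitor), compound 1 gives 450 nM. Compound 2 `O=C(Nc1ccc(Oc2ccnc3[nH]ccc23)cc1)c1cn(-c2ccc(Cl)cc2)c2ccccc2c1=O` carries a chloro instead and gives 250 nM, which amounts to a 1.8-fold lower number from compound 1 to compound 2 (0.26 log units; within the scatter). Compound 3 `O=C(Nc1ccc(Oc2ccnc3[nH]ccc23)cc1)c1cn(-c2ccc(Br)cc2)c2ccccc2c1=O` carries a bromo and gives 220 nM; this is a 2.0-fold lower number from compound 1 to compound 3 (0.31 log units; beyond the scatter), while there is only a 1.1-fold lower number from compound 2 to compound 3 (0.06 log units; within the scatter). On the numbers shown, compound 3 holds the lowest value of the three, set apart from compound 1 beyond the scatter but from compound 2 only within it, so it cannot be called the strongest inhibitor outright.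

Compound 4 `O=C(Nc1ccc(Oc2ccnc3[nH]ccc23)cc1)c1cn(-c2ccc(Br)cc2F)c2ccccc2c1=O` differs from compound 3 by fluoro in place of hydrogen on an aromatic carbon, so that 4-bromophenyl becomes 4-bromo-2-fluorophenyl. None of the three measured steps bears directly on this change: each of them exchanges one halogen for another at a single place, and even the largest of them was modest. The bromo group of compound 3 is kept in compound 4, so the step is expected to be no change at the digits printed from compound 3 to compound 4 (within the scatter), with no change beyond the scatter. Compound 4 is therefore estimated at 220 nM, within a range from 100 nM to 500 nM.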

Compound 4, half-maximal inhibitory concentration: 790 nM
Compound 4: middle estimate off by 3.6-fold (0.56 log units), on the low side; the whole stated range lies below it.
By their numbers in this assay, from the lowest: compounds 3, 2, 1 and 4 (each within the scatter of the next, the first and the last beyond it).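

In this assay, fluoro in place of hydrogen on an aromatic carbon, ortho to a large group and meta to a bromo group, gives a 3.6-fold higher number from compound 3 to compound 4 (0.56 log units; beyond the scatter). For the compounds shown here, this is the first change to raise the number beyond the scatter, and it comes from a site that carries hydrogen in the earlier compounds, whereas their halogen exchanges at a single place gave lower numbers or none that could be told apart. Against the other two compounds, the 4-bromo-2-fluorophenyl group gives a 3.2-fold higher number from compound 2 to compound 4 (0.50 log units; beyond the scatter) but only a 1.8-fold higher number from compound 1 to compound 4 (0.24 log units; within the scatter), so the added fluoro separates compound 4 from compound 2 while leaving it inside the scatter of compound 1, and no measurement at hand accounts for this rise.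

Going by these compounds, what a methyl, a methoxy or an amine would do on this same aromatic carbon remains open, so the step cannot be assigned to fluoro in particular rather than to any group there. On these data alone, it is also open whether the same fluoro would give a step of this size alongside a chloro in place of the bromo.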